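The source may report more compounds than this note shows. Statements on the series, on what has been measured and on what is new or still open speak of the compounds shown alone.

Measured compounds:
`NS(=O)(=O)c1ccc(N2N=C(c3ccc(F)cc3)CC2c2cn(-c3ccccc3)nc2-c2ccc(F)cc2)cc1` compound 1, an ADME assay on Vero cells (Chlorocebus sabaeus) for cytotoxicity, read by MTT assay, with a stated time of 72 h; on this read-out higher numbers stand for lower toxicity in this test and lower numbers for higher toxicity in this test: > 753000 nM
`COc1ccc(C2=NN(c3ccc(S(N)(=O)=O)cc3)C(c3cn(-c4ccccc4)nc3-c3ccc(F)cc3)C2)cc1` compound 2, this assay: > 53100 nM

Compound 2 stands at a limit of this assay rather than at a number, since in this assay compound 2 gives > 53100 nM. Compound 1 also stands at a limit of this assay, where compound 1 gives > 753000 nM. Going by the values given here, the one measured step, a step that the two limits leave unreadable from compound 1 to compound 2, cannot be sized because both ends are limits, as the limit of > 53100 nM in this assay, at which 1 of the 2 values shown sits, and the limit of > 753000 nM in this assay, at which 1 of the 2 values shown sits, show.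

Compound 3, `COc1ccc(C2=NN(c3ccc(S(N)(=O)=O)cc3)C(c3cn(-c4ccccc4)nc3-c3ccc(OC)cc3)C2)cc1`, differs from compound 2 by methoxy in place of fluoro on an aromatic carbon. This is the same kind of exchange, methoxy in place of fluoro on an aromatic carbon, as the step from compound 1 to compound 2, and that step gave no readable size. Nothing measured therefore points to a shift beyond the scatter, and the expectation is that compound 3 again reaches only a limit of this assay. The step from compound 2 to compound 3 is expected to be a step that the limit leaves unreadable from compound 2 to compound 3. Compound 3 is estimated at 60000 nM, with a range from 30000 nM to 800000 nM.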

Compound 3, half-maximal cytotoxic concentration: 104000 nM
Beside the measured number, compound 3's estimate is 1.7-fold (0.24 log units) below it; low and high end bracket the measured number.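

The step from compound 2 to compound 3 cannot be sized, because compound 2 stands only at a limit of this assay: the limit of > 53100 nM in this assay, at which 1 of the 3 values shown sits.

The compounds shown leave open whether methoxy in place of fluoro on an aromatic carbon shifts this read-out at all, in either of the two exchanges.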